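Lengthening the propoxy chain of compound 2

This account rests on a few compounds, and the source may have more. Where it says the series, first, only, none or still open, it means among the compounds named here.

In a functional assay on the whole organism with Canis familiaris (Canis lupus familiaris) as the target (on this read-out higher numbers stand for an effect only at larger amounts of compound and lower numbers for an effect already at smaller amounts), compound 1 `CS(=O)(=O)c1ccc(-c2nc3ccc[nH]c-3n2)cc1` gives 18 mg/kg and compound 2 `CCCOc1cc(OC)ccc1-c1nc2cc[nH]cc-2n1` gives 1.3 mg/kg as the lower of the two numbers, a gap beyond the scatter. Compound 3 `CCSCCOc1cc(OC)ccc1-c1nc2cc[nH]cc-2n1` differs from compound 2 by ethylsulfanyl in place of methyl on a saturated chain carbon, two bonds along the chain from an oxygen on an aromatic ring and so turns propoxy to 2-(ethylsulfanyl)ethoxy. For the measured compounds named here, no measured pair shows this change, so the expectation rests on the structural change alone. In this assay the expected 1.2-fold higher number from compound 2 to compound 3 (0.09 log units; within the scatter) stays within the scatter, with only a slight lean towards higher numbers. Compound 3 is estimated at 1.6 mg/kg (expected range 0.5 mg/kg to 5 mg/kg) in this read-out.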

Compound 3, dose for half-maximal effect: 1 mg/kg
Compound 3: middle estimate off by 1.6-fold (0.20 log units), on the high side; measured number inside the range.
By their numbers in this assay, from the lowest: compounds 3 and 2 (each within the scatter of the next); then compound 1.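

In this assay, ethylsulfanyl in place of methyl on a saturated chain carbon, two bonds along the chain from an oxygen on an aromatic ring, gives a 1.3-fold lower number from compound 2 to compound 3 (0.11 log units; within the scatter) for the series, the first step read at this position. The position therefore accepts the change from propoxy to 2-(ethylsulfanyl)ethoxy without a step beyond the scatter. Nothing at hand bears on the reason for this result.

Open, going by these compounds, is whether the sulfur matters, as against an all-carbon chain of the same length. Also open, on these data alone, is whether an amine or a carboxylic acid on this chain would hold the number in this assay.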